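Methyl added to the 4-methylphenyl ring of compound 2

This account rests on a few compounds, and the source may have more. Where it says the series, first, only, none or still open, it means among the compounds named here.

Compound 1 `Cc1nc(-c2ccccc2)c(C(=O)N2CCN(c3cccc(C(N)=O)c3)CC2)o1`: 71 nM
Compound 2 `Cc1ccc(N2CCN(C(=O)c3oc(C)nc3-c3ccccc3)CC2)cc1`: > 1000 nM, a limit

In a functional assay on HL-60 cells (Homo sapiens) for inhibition, read by MTT assay, with a stated time of 72 h (on this read-out lower numbers stand for stronger inhibition and higher numbers for weaker inhibition), compound 2 stands only at a limit, > 1000 nM. Compound 3 `Cc1ccc(N2CCN(C(=O)c3oc(C)nc3-c3ccccc3)CC2)c(C)c1` carries methyl in place of hydrogen on an aromatic carbon, ortho to a large group and meta to a methyl group (methyl in place of hydrogen on an aromatic carbon). Going by the values given here, the one measured step bearing on this is an at least 14-fold higher number from compound 1 to compound 2 (1.14 log units; beyond the scatter), a large step at the same ring nitrogen substituent. That substituent in compound 3 is 2,4-dimethylphenyl, with no 3-carbamoylphenyl restored, so no step beyond the scatter is expected in this assay, in either direction. The expected step is a step that the limit leaves unreadable from compound 2 to compound 3. Compound 3 is estimated at 1500 nM, with an expected range of 500 nM to 5000 nM.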

Compound 3, half-maximal inhibitory concentration: 101 nM
The estimate for compound 3 lay 15-fold (1.17 log units) above the measured number; measured number outside the range, below it.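

In this assay, methyl on this aromatic carbon, ortho to a large group, brings an at least 9.9-fold lower number from compound 2 to compound 3 (0.99 log units; beyond the scatter), so this single position strongly affects the series. That size is only a bound, as compound 2 stands at a limit: the limit of > 1000 nM in this assay, at which 1 of the 3 values shown sits. With 2,4-dimethylphenyl in place of 3-carbamoylphenyl there is a 1.4-fold higher number from compound 1 to compound 3 (0.15 log units; within the scatter), so the carbamoyl group is not needed for inhibition at this level.

Going by these compounds, whether chlorine, methoxy or ethyl at this carbon would serve as methyl does remains open. So does whether the gain depends on the methyl group already on the ring.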